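Aryl amine series: fluoro to amino on the aryl ring

The source may hold more compounds than are shown below. What is called first, only, known or untested is meant among the compounds shown, and "the series" means these compounds.

Measured so far:
compound 1, `Cc1nc(Nc2ccc(F)cc2)c2cc[nH]c2n1`, 372000000 nM
compound 2, `Cc1ccc(Nc2[nH]c(C)nc3nccc2-3)cc1`, 759000000 nM

Of the compounds shown here, two have been tested in a functional assay on the whole organism for inhibition, with Nicotiana tabacum as the target; a higher number here means a weaker inhibitor, a lower number a stronger inhibitor. Compound 1 gives 372000000 nM, the lowest of the two numbers. Compound 2 gives 759000000 nM, a number that lies beyond the scatter of compound 1. The two structures differ in more than one place, so no single change can be tied to that gap.

Compound 3, `Cc1nc(Nc2ccc(N)cc2)c2cc[nH]c2n1`, has not been measured. It is derived from compound 1 by one change: amino in place of fluoro on an aromatic carbon. The shared core and the aryl amine link are kept.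

Among the measured compounds shown here, no measured pair isolates this exchange, so nothing in the data says how large its step should be or in which direction. The working expectation is therefore a step of no more than the scatter, a 1.1-fold higher number from compound 1 to compound 3 (0.03 log units; within the scatter), with the range left wide. Compound 3 is estimated at 400000000 nM in this assay, with a range from 150000000 nM to 1100000000 nM.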

Compound 3, half-maximal inhibitory concentration: 195000000 nM
Compound 3: the middle estimate sits 2.1-fold (0.31 log units) above what was measured, within the range that was stated.
By their numbers in this assay, from the lowest: compounds 3 and 1 (each within the scatter of the next); then compound 2.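

In this assay, among the compounds shown here, the exchange of fluoro for amino on the aromatic carbon para to a large group gives a 1.9-fold lower number from compound 1 to compound 3 (0.28 log units; within the scatter), the first step that can be tied to a single change. At this position, the entering amino counts 1 hydrogen-bond donor and 1 hydrogen-bond acceptor and the leaving fluoro counts neither, yet the two compounds stay within the scatter of each other, so this difference in counts comes with no readable separation in this pair. Nothing available bears on why the two groups read so alike.

Still open, going by these compounds, is whether any other group at this position, such as a carboxylic acid, a nitrile or a longer chain, would give a step beyond the scatter, since one pair within the scatter does not define what the position allows. Also open, on these data alone, is whether the step between fluoro and amino would stay the same on another aromatic carbon of the ring or with another group in place of the methyl on the shared core.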